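A Chloro Substituent on an Amide That Shows No Toxicity

A few compounds are considered here, and "the series" means these few. Any claim that something is new, unique, unknown or untested is made for them only; others in the source may bear on it.

Compound 1 `Cn1c(-c2ccccc2)cnc1NC(=O)c1ccccc1` is an aromatic amide on a small shared core, and it was tested in a toxicity assay on THP-1 cells (Homo sapiens) for inhibition; on this read-out higher numbers stand for lower toxicity in this test and lower numbers for higher toxicity in this test. In this assay compound 1 gives > 100000 nM, which is a limit of the assay rather than a measured number. Two related compounds were run in the same test. Compound 2 `Cn1c(-c2cccc(C#N)c2)cnc1NC(=O)c1ccc(F)cc1` carries a nitrile and a fluorine, and in this assay compound 2 gives > 100000 nM, again a limit. Compound 3 `COc1ccc(-c2cnc(NC(=O)C3CCCC3)n2C)cc1` has a cyclopentyl amide and a methoxy group, and in this assay compound 3 gives > 100000 nM, also a limit. Compound 1 therefore sits exactly where its neighbours sit: the limit of > 100000 nM in this assay, at which 3 of the 3 values shown sit.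

Compound 4 `Cn1c(-c2ccccc2)cnc1NC(=O)c1cccc(Cl)c1` is the compound still to be measured. It differs from compound 1 by a single change: chloro in place of hydrogen on an aromatic carbon, which cut one bond further out reads phenyl to 3-chlorophenyl. For the measured compounds named here, no measured pair in this set shows what such a change does here, so the expectation rests on the three limits alone. In this assay the expected step that the limit leaves unreadable from compound 1 to compound 4 is none beyond the scatter. Compound 4 is estimated at 150000 nM, within a range from 60000 nM to 400000 nM, and the assay will most likely again report only a limit.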

Compound 4, half-maximal cytotoxic concentration: > 50000 nM
Compound 4 ended at the assay's limit; the forecaster's own chance of this, stated with the estimate: 80%; the middle value lies beyond the limit too.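

Compound 1 and compound 4 are both reported in this assay only as limits, not as measured numbers, so no step can be read for chloro in place of hydrogen on an aromatic carbon. The compounds shown leave open whether chloro changes the result in this assay at all, and whether any of these compounds would give a measurable value there.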